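The compounds below may be only part of what the source reports. "The series", "measured", "known", "first", "only" and "open" are said of these compounds alone.

Three compounds have been measured in a functional assay on SMMC-7721 cells (Homo sapiens) for inhibition, read by MTT assay, with a stated time of 48 h; a lower number here means a stronger inhibitor, a higher number a weaker inhibitor:

compound 1 `CN(c1ncccc1CNc1nc(Nc2ccc3c(c2)CC(=O)N3)nc2[nH]ccc12)S(C)(=O)=O`, which gives 52800 nM
compound 2 `Cc1c[nH]c2nc(Nc3ccc4c(c3)CC(=O)N4)nc(NCc3cccnc3N(C)S(C)(=O)=O)c12`, which gives 18700 nM
compound 3 `CN(c1ncccc1CNc1nc(Nc2ccc(F)cc2)nc2[nH]cc(F)c12)S(C)(=O)=O`, which gives 27900 nM

Compound 3 stands second highest of the three numbers. Its nearest neighbour is compound 2 and its furthest is compound 1, and both of those values lie within the scatter of compound 3, so no order among the three can be claimed beyond that position.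

Compound 4 `COc1cccc(Nc2nc(NCc3cccnc3N(C)S(C)(=O)=O)c3c(F)c[nH]c3n2)c1C` differs from compound 3 by 3-methoxy-2-methylphenyl in place of 4-fluorophenyl on a nitrogen on an aromatic ring. The only step measured among these compounds is a 2.8-fold lower number from compound 1 to compound 2 (0.45 log units; beyond the scatter), a change of a methyl for a hydrogen on an aromatic carbon of the shared core, not on the nitrogen where compound 4 differs from compound 3; it does not bear on the present change. For the measured compounds named here, no measured pair in this set varies the group on that nitrogen, so the expectation rests on the narrow spread of the three values. Compound 4 is therefore expected to give a number close to that of compound 3, with a 1.1-fold lower number from compound 3 to compound 4 (0.05 log units; within the scatter), no step beyond the scatter. Compound 4 is estimated at 25000 nM, within a range from 8000 nM to 80000 nM; the range is wide, as this change has no measured precedent among these compounds.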

Compound 4, half-maximal inhibitory concentration: > 100000 nM
Compound 4 gave a limit, no number; the forecaster's own chance of this, stated with the estimate: 10%; at least 4.0-fold (0.60 log units) between middle value and limit.
By their numbers in this assay, from the lowest: compounds 2, 3 and 1 (each within the scatter of the next, the first and the last beyond it). At a limit, above all of these: compound 4.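

In this assay, the group on the nitrogen on an aromatic ring proves to matter: 3-methoxy-2-methylphenyl in place of 4-fluorophenyl gives an at least 3.5-fold higher number from compound 3 to compound 4 (0.55 log units; beyond the scatter), the first change at this position among the compounds shown. Compound 4 is reported only as a limit of the assay, not as a number, so the full size of this step cannot be read: the limit of > 100000 nM in this assay, at which 1 of the 4 values shown sits. For the compounds shown here, the position is thus not indifferent to the group it carries, something the earlier compounds, which all left this kind of change untested, could not show.

The compounds shown do not separate the methoxy from the methyl, which enter together, so either could carry the step. Going by these compounds, whether a phenyl ring with only one of the two, or with an amine, would give a number like that of compound 3 stays open.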